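Methylating a Phenol in a Stilbene: Expected Cytotoxicity

This account rests on a few compounds, and the source may have more. Where it says the series, first, only, none or still open, it means among the compounds named here.

Measured compounds:
Compound 1, `COc1cc(O)cc(/C=C/c2ccc(O)c(OC)c2OC)c1`, gives > 100000 nM in an ADME assay on QSG7701 cells (Homo sapiens) for cytotoxicity, read by MTT assay, with a stated time of 24 h (on this read-out lower numbers stand for stronger inhibition and higher numbers for weaker inhibition), a limit of the assay and not a number.
Compound 2, `COc1cc(O)cc(/C=C/c2cccc(O)c2O)c1`, gives > 100000 nM in this assay, likewise a limit and not a number.

Among the measured compounds shown here, compound 2 therefore stands at the edge of what this assay can report, and the only other value shown sits at the same place: the limit of > 100000 nM in this assay, at which 2 of the 2 values shown sit. For the measured compounds named here, no step between measured compounds can be computed here, so nothing measured tells how a single change moves this read-out.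

Compound 3, `COc1cc(O)cc(/C=C/c2cccc(O)c2OC)c1`, is the unmeasured partner of compound 2. It differs by a single change: methyl in place of hydrogen on an oxygen on an aromatic ring.

With both measured values sitting at the limit, the expectation for compound 3 is that the step that the limit leaves unreadable from compound 2 to compound 3 stays within the usual scatter, with no clear direction. Compound 3 is estimated at 150000 nM, within a range from 50000 nM to 500000 nM, and most likely the assay again reports only a limit.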

Compound 3, half-maximal inhibitory concentration: > 100000 nM
Compound 3: a limit, no number; the forecaster's own chance of this, stated with the estimate: 80%; the middle value lies beyond the limit too.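

The step from compound 2 to compound 3 cannot be read, since each gives only a limit and not a number in this assay: the limit of > 100000 nM in this assay, at which 3 of the 3 values shown sit.

The compounds shown leave open whether methyl in place of hydrogen on an oxygen on an aromatic ring moves this read-out at all.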